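The source may hold more compounds than are shown below. What is called first, only, known or untested is meant among the compounds shown, and "the series" means these compounds.

Among the measured compounds shown here, compound 2 `Cc1nc(S(C)(=O)=O)ccc1Oc1ncnc(OC2CCN(C(=S)OC(C)C)CC2)c1F` stands at the highest of the two numbers measured so far: in a functional assay on isolated protein for inhibition of Glucose-dependent insulinotropic receptor (Rattus norvegicus), read by HTRF and cAMP accumulation (a lower number here means that less compound is needed, a higher number that more compound is needed for the effect), compound 2 gives 1050 nM, while its nearest neighbour, compound 1 `Cc1nc(S(C)(=O)=O)ccc1Oc1ncnc(OC2CCN(C(=O)O[C@@H](C)C(F)(F)F)CC2)c1F`, gives 109 nM. Compound 3 `Cc1nc(S(C)(=O)=O)ccc1Oc1ncnc(OC2CCN(C(=O)c3noc(C(C)C)n3)CC2)c1F` carries a group of 10 heavy atoms (6 carbon, 2 nitrogen, 2 oxygen; one five-membered aromatic ring with 3 hetero atoms) in place of a group of 6 heavy atoms (4 carbon, 1 oxygen, 1 sulfur; no ring), on an amine nitrogen in a ring. For the measured compounds named here, only one measured step touches this position, and only loosely: a 9.6-fold higher number from compound 1 to compound 2 (0.98 log units; beyond the scatter), a swap of groups on the same ring nitrogen. Since that position has already moved the number well beyond the scatter, a step back toward a lower number in this assay is expected for compound 3, of about a 4.2-fold lower number from compound 2 to compound 3 (0.62 log units; beyond the scatter). Compound 3 is therefore estimated at 250 nM, within a range from 60 nM to 1000 nM.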

Compound 3, half-maximal effective concentration: 176 nM
Estimate against measurement, compound 3: 1.4-fold (0.15 log units) above; the measured number falls inside the stated range.
By their numbers in this assay, from the lowest: compounds 1 and 3 (each within the scatter of the next); then compound 2.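

In this assay, replacing the sulfur-containing group of compound 2 with the oxadiazole-bearing group on the ring nitrogen gives a 6.0-fold lower number from compound 2 to compound 3 (0.78 log units; beyond the scatter), so this position can regain the lower number with a ring-bearing group. Placing 5-isopropyl-1,2,4-oxadiazol-3-yl instead of 1-(trifluoromethyl)ethoxy on the carbonyl carbon gives a 1.6-fold higher number from compound 1 to compound 3 (0.21 log units; within the scatter), so these two quite different groups cannot be told apart here. Nothing available explains either step. The compounds shown leave open whether the isopropyl or the oxadiazole ring itself matters, and how a methyl or tert-butyl group on that ring, or a phenyl ring on the carbonyl carbon, would read.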